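A few compounds are considered here, and "the series" means these few. Any claim that something is new, unique, unknown or untested is made for them only; others in the source may bear on it.

In an ADME assay on cells (Hepatocyte, Rattus norvegicus) for metabolic stability (on this read-out higher numbers stand for fast clearance and lower numbers for slow clearance), two compounds have been measured so far. Compound 1 `CC(C)n1nc(-c2ccnc3[nH]c(C4CCN(CC(=O)N(C)C)CC4)cc23)ccc1=O` gives 3.1 uL/min. Compound 2 `CC(C)n1cc(-c2ccnc3[nH]c(C4CCN(CC(=O)N5CCCC5)CC4)cc23)ccc1=O` gives 5.4 uL/min, the higher of the two numbers, although the gap to compound 1 falls within the usual scatter of repeated measurements, so the two cannot be told apart on these data. The two compounds differ from each other in more than one place, so their values are set side by side without drawing a step between them.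

Compound 3 `CC(C)n1cc(-c2ccnc3[nH]c(C4CCN(CC(=O)N(C)C)CC4)cc23)ccc1=O` has not yet been measured in this assay. It is made from compound 2 by one change, described as dimethylamino in place of pyrrolidin-1-yl on a carbonyl carbon, sitting on a carbonyl carbon whose other neighbour is a saturated chain carbon. The same dimethylamino group on a carbonyl carbon is already present in compound 1, whose value of 3.1 uL/min is close to that of compound 2.

For the measured compounds named here, with no measured step of this kind available, the step from compound 2 to compound 3 is expected to be small, a 1.3-fold lower number from compound 2 to compound 3 (0.11 log units; within the scatter), and within the scatter in either direction. Compound 3 is therefore estimated at 4.2 uL/min, with a range from 2 uL/min to 9 uL/min.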

Compound 3, intrinsic clearance in a liver preparation (reported as CLH), per the amount of preparation that the assay uses: 2.3 uL/min
For compound 3 the middle estimate is 1.8-fold (0.26 log units) above the measured one; measured number inside the range.
By their numbers in this assay, from the lowest: compounds 3, 1 and 2 (each within the scatter of the next, the first and the last beyond it).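

In this assay, for the compounds shown here, the exchange of pyrrolidin-1-yl for dimethylamino on a carbonyl carbon gives the first single-change comparison at this position: a 2.3-fold lower number from compound 2 to compound 3 (0.37 log units; beyond the scatter) is a modest step, but it lies beyond the scatter, so this smaller open-chain group goes with slower clearance in this pair. The other comparison keeps dimethylamino fixed and changes a group on an aromatic carbon, replacing a six-membered aromatic ring with 2 hetero atoms by one with 1 hetero atom; a 1.3-fold lower number from compound 1 to compound 3 (0.13 log units; within the scatter) lies within the scatter, so that change cannot be told apart in this read-out. Nothing measured here explains why either comparison comes out as it does.

From the compounds shown here alone, one pair cannot show whether the step follows ring size, ring presence or something else, and that remains open for other groups on the same carbonyl carbon, such as azetidin-1-yl, piperidin-1-yl or morpholin-4-yl. Going by these compounds, it also remains open whether exchanging dimethylamino for pyrrolidin-1-yl on the core of compound 1 would give a step of similar size.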